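This account rests on a few compounds, and the source may have more. Where it says the series, first, only, none or still open, it means among the compounds named here.

Compound 3 `COc1cc2c(Oc3ccc(NC(=O)c4cc(-c5ccc(C)cc5)ccn4)cc3F)ccnc2cc1OCCCN1CCCC1` gives 350 nM in a functional assay on HT-29 cells (Homo sapiens) for cytotoxicity, read by MTT assay, with a stated time of 72 h (on this read-out lower numbers stand for stronger inhibition and higher numbers for weaker inhibition), the lowest of the three numbers in hand. Compound 1 `COc1cc2c(Oc3ccc(NC(=O)c4cc(-c5ccc(F)cc5)ccn4)cc3F)ccnc2cc1OCCCN1CCCCC1` gives 1370 nM and compound 2 `COc1cc2c(Oc3ccc(NC(=O)c4cc(-c5ccc(F)cc5)ccn4)cc3F)ccnc2cc1OCCCN1CCN(C)CC1` gives 1460 nM; each of those stands beyond the scatter from compound 3. Compound 4 `COc1cc2c(Oc3ccc(NC(=O)c4cc(-c5ccc(F)cc5)ccn4)cc3F)ccnc2cc1OCCCN1CCCC1` differs from compound 3 by fluoro in place of methyl on an aromatic carbon. Within the data shown here, no measured step changes this group on its own. Among the measured compounds shown here, the one single-point step in hand, a 1.1-fold higher number from compound 1 to compound 2 (0.03 log units; within the scatter), concerns the amine at the end of the saturated chain and says nothing about the substituent on the pendant aromatic ring. Compound 1 and compound 3 differ at two places at once, that substituent and the chain-end amine, so their gap cannot be split between the two. Compound 4 carries the 4-fluorophenyl of compound 1 together with the chain-end amine of compound 3, so a number between those two compounds is expected, a step of a 2.3-fold higher number from compound 3 to compound 4 (0.36 log units; beyond the scatter). Compound 4 is estimated at 800 nM in this assay, with a range of 300 nM to 2500 nM.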

Compound 4, half-maximal inhibitory concentration: 430 nM
Compound 4: middle estimate off by 1.9-fold (0.27 log units), on the high side, and the stated range covers the measured number.
By their numbers in this assay, from the lowest: compounds 3 and 4 (each within the scatter of the next); then compounds 1 and 2 (each within the scatter of the next).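

In this assay, fluoro in place of methyl at this position, para to a large group, gives a 1.2-fold higher number from compound 3 to compound 4 (0.09 log units; within the scatter) and so separates 4-fluorophenyl from 4-methylphenyl by no more than the usual scatter. With 4-fluorophenyl held fixed, the chain-end amine does produce steps beyond the scatter: pyrrolidin-1-yl in place of piperidin-1-yl gives a 3.2-fold lower number from compound 1 to compound 4 (0.50 log units; beyond the scatter) and pyrrolidin-1-yl in place of 4-methylpiperazin-1-yl gives a 3.4-fold lower number from compound 2 to compound 4 (0.53 log units; beyond the scatter) in this series. Nothing available accounts for the size of these steps.

As far as these compounds go, whether the pendant ring position stays this flat with a larger group such as trifluoromethyl or methoxy remains open. Also open, from the compounds shown here alone, is how a morpholin-4-yl or dimethylamino group at the chain end, or a shorter chain, would compare with pyrrolidin-1-yl.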